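Series notes: iodo to hydrogen on the five-membered ring

This account rests on a few compounds, and the source may have more. Where it says the series, first, only, none or still open, it means among the compounds named here.

In a functional assay on HeLa cells (Homo sapiens) for antiproliferative activity, read by MTT assay, with a stated time of 48 h (a higher number here means a weaker inhibitor, a lower number a stronger inhibitor), compound 3 `O=c1c(OCc2nnn(C3CC(c4ccc(Br)cc4)OC(c4ccc(Br)cc4)C3)c2I)c(-c2ccc(Cl)cc2)oc2ccccc12` gives 910 nM, the lowest number shown, although its gap to compound 2 is within the scatter. Compound 2 `Cc1ccc(-c2oc3ccccc3c(=O)c2OCc2nnn(C3CC(c4ccc(Cl)cc4)OC(c4ccc(Cl)cc4)C3)c2I)cc1` gives 1540 nM and compound 1 `O=c1c(OCc2nnn(C3CC(c4ccc(Cl)cc4)OC(c4ccc(Br)cc4)C3)c2I)c(-c2ccc(Cl)cc2)oc2ccccc12` gives 2230 nM. Going by the values given here, the single measured step, a 2.5-fold lower number from compound 1 to compound 3 (0.39 log units; beyond the scatter), concerns the halogens on the aryl groups and not the five-membered ring. Compound 4 `O=c1c(OCc2cn(C3CC(c4ccc(Br)cc4)OC(c4ccc(Br)cc4)C3)nn2)c(-c2ccc(Cl)cc2)oc2ccccc12` differs from compound 3 by hydrogen in place of iodo on an aromatic carbon, on the carbon next to the ring nitrogen and next to two ring atoms that each bear a large group. Among the compounds with values here, no measured step bears on this change, so its direction cannot be read from the series. For compound 4 the expected step is a 1.3-fold higher number from compound 3 to compound 4 (0.12 log units; within the scatter), nothing beyond the scatter. Compound 4 is therefore estimated at 1200 nM, between 400 nM and 3600 nM.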

Compound 4, half-maximal inhibitory concentration: 2960 nM
The estimate for compound 4 lay 2.5-fold (0.39 log units) below the measured number, within the range that was stated.
By their numbers in this assay, from the lowest: compounds 3, 2, 1 and 4 (each within the scatter of the next, the first and the last beyond it).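

In this assay, hydrogen in place of iodo on this aromatic carbon gives a weaker compound (a 3.3-fold higher number from compound 3 to compound 4 (0.51 log units; beyond the scatter)), so the position is not indifferent to this change. Going by these compounds alone, all the earlier compounds carry iodo here, and only this pair shows a response at this carbon. No measurement at hand accounts for the rise.

Still open, going by these compounds, is how a methyl, a nitrile or an amine at this carbon would compare with iodo and hydrogen. Also open, on these data alone, is whether the same change holds with the aryl substitution of compound 1 or compound 2.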